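From 2,3-dimethylphenyl to 3-fluorophenyl at the assay limit

The source may hold more compounds than are shown below. What is called first, only, known or untested is meant among the compounds shown, and "the series" means these compounds.

Values measured so far in a functional assay on HeLa cells (Homo sapiens) for inhibition, read by MTT assay, with a stated time of 72 h (a higher number here means a weaker inhibitor, a lower number a stronger inhibitor), are these:
Compound 1 (`Cc1cccc(NC(=O)Nc2ccc(Oc3ncnc4[nH]ncc34)cc2)c1C`) gives > 10000 nM
Compound 2 (`O=C(Nc1ccc(C(F)(F)F)cc1)Nc1cccc(Oc2ncnc3[nH]ncc23)c1`) gives > 10000 nM

Compound 1 has no exact number here, only a limit (> 10000 nM). Compound 2 likewise has only a limit (> 10000 nM). These two results are the whole record so far (the limit of > 10000 nM in this assay, at which 2 of the 2 values shown sit), so neither compound can be ranked against the other.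

Compound 3 (`O=C(Nc1ccc(Oc2ncnc3[nH]ncc23)cc1)Nc1cccc(F)c1`) keeps the core of compound 1 but carries 3-fluorophenyl in place of 2,3-dimethylphenyl on an amide-type nitrogen. Among the measured compounds shown here, no pair of measured compounds shows what a change of this kind does in this assay. The expected step (a number no higher from compound 1 to compound 3 (the limit leaves the size open)) is none beyond the scatter, and no direction is favoured. That expectation rests on the only starting point available, compound 1, whose result is a limit (> 10000 nM). Compound 3 is estimated at 10000 nM within an expected range from 3000 nM to 30000 nM in this assay. Compound 3 may be expected to give only a limit again.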

Compound 3, half-maximal inhibitory concentration: > 10000 nM
Compound 3: a limit, no number; the forecaster's own chance of this, stated with the estimate: 65%; the middle value sits exactly at the limit.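

Compound 3 gives > 10000 nM, which is a limit and not a number. Compound 1 also has only a limit, so the swap of 2,3-dimethylphenyl for 3-fluorophenyl between compound 1 and compound 3 gives no readable step: the limit of > 10000 nM in this assay, at which 3 of the 3 values shown sit.

The compounds shown leave open how these groups compare, since none of them gives an exact number.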